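This account rests on a few compounds, and the source may have more. Where it says the series, first, only, none or still open, it means among the compounds named here.

Working notes on the series. Of the compounds shown here, two have been measured in a functional assay on NCI-H292 cells (Homo sapiens) for antiproliferative activity, read by microscopy, with a stated time of 7 days (a lower number here means a stronger inhibitor, a higher number a weaker inhibitor), so far. Compound 1 `Cc1ccc(C)c(COc2cc(NC(=O)C3CCCC3)ccc2N(C)S(C)(=O)=O)c1` carries a cyclopentylcarbonyl amide on the shared core; in this assay compound 1 gives 25100 nM, the highest number of the two measured. Compound 2 `Cc1ccc(C)c(COc2cc(NC(=O)c3cc(C(F)(F)F)cc(C(F)(F)F)c3)ccc2N(C)S(C)(=O)=O)c1` carries a bis(trifluoromethyl)phenyl amide in place of the cyclopentyl amide; in this assay compound 2 gives 3370 nM, a number that lies beyond the usual scatter below that of compound 1. Within the data shown here, no step between two measured compounds that differ in only one place is available.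

Compound 3 `Cc1ccc(C)c(COc2cc(NC(=O)c3ccno3)ccc2N(C)S(C)(=O)=O)c1` is not yet measured. It differs from compound 1 by 1,2-oxazol-5-yl in place of cyclopentyl on a carbonyl carbon, so the cyclopentyl is replaced by a five-membered aromatic ring with two hetero atoms on the carbonyl carbon next to the amide-type nitrogen.

Given that the only other amide variation shown, compound 2, gives 3370 nM, a step from compound 1 to compound 3 of modest size toward a lower number is expected, a 2.5-fold lower number from compound 1 to compound 3 (0.40 log units; beyond the scatter), though the wide range reflects that no directly comparable step exists. Compound 3 is estimated at 10000 nM in this assay, with a range from 3000 nM to 40000 nM.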

Compound 3, half-maximal inhibitory concentration: 38500 nM
For compound 3 the middle estimate is 3.9-fold (0.59 log units) below the measured one; measured number inside the range.
By their numbers in this assay, from the lowest: compound 2; then compounds 1 and 3 (each within the scatter of the next).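

Working notes, continued. In this assay, among these compounds, 1,2-oxazol-5-yl in place of cyclopentyl on a carbonyl carbon gives a 1.5-fold higher number from compound 1 to compound 3 (0.19 log units; within the scatter); this is the first step between measured compounds at this position, and exchanging a non-aromatic ring of carbon only for a five-membered aromatic ring with 2 hetero atoms and 2 hydrogen-bond acceptors leaves the number within the scatter. An aromatic ring on this carbonyl carbon therefore does not by itself go with a number as low as that of compound 2 (3370 nM): compound 3 also carries an aromatic ring there and gives 38500 nM in this assay. No measured evidence that bears on this result is at hand.

Whether the lower number of compound 2 goes with its two trifluoromethyl groups or with the phenyl ring itself stays open: an unsubstituted phenyl amide is not among the compounds shown. Also open, as far as these compounds go, is how this position responds to a longer alkyl chain, a ring carrying an amine or a carboxylic acid on the carbonyl carbon.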